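The source may hold more compounds than are shown below. What is called first, only, known or untested is meant among the compounds shown, and "the series" means these compounds.

Compound 1 `Cc1nnc(SCc2coc3ccc(Cl)cc3c2=O)o1` was tested in a functional assay on MCF7 cells (Homo sapiens) for cytotoxicity, read by MTT assay, with a stated time of 72 h (on this read-out lower numbers stand for stronger inhibition and higher numbers for weaker inhibition), and gave 5000 nM. Compound 2 `Cc1cc(C)n2nc(SCc3nnc(SCc4cc(=O)c5ccccc5o4)o3)nc2n1` shares the chromenone portion of the core with compound 1 but carries a different heteroaromatic arm; in this assay compound 2 reached only a limit of the assay, at > 25000 nM. Among the two values shown, that of compound 1 is therefore the only actual number, and the other sits at the limit of > 25000 nM in this assay, at which 1 of the 2 values shown sits; no step between two measured compounds can be computed from them.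

Compound 3 `Cc1nnc(SCc2coc3ccc(Cl)cc3c2=O)s1` differs from compound 1 in one place: 5-methyl-1,3,4-thiadiazol-2-yl in place of 5-methyl-1,3,4-oxadiazol-2-yl on a sulfur. The heteroaromatic ring keeps its size, its count of hetero atoms and its acceptor count, and one ring atom changes from oxygen to sulfur. For the measured compounds named here, with no measured pair in this set carrying such a swap, the account expects that the step from compound 1 to compound 3 in this assay, a 1.1-fold lower number from compound 1 to compound 3 (0.05 log units; within the scatter), will stay within the usual scatter of repeated measurements, with no clear direction. Compound 3 is accordingly estimated to give 4500 nM in this assay, within a range from 1500 nM to 13000 nM.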

Compound 3, half-maximal inhibitory concentration: 13400 nM
Compound 3: the middle estimate sits 3.0-fold (0.47 log units) below what was measured; the measured number lies above the stated range.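

In this assay the exchange of one ring atom, oxygen for sulfur, gives a 2.7-fold higher number from compound 1 to compound 3 (0.43 log units; beyond the scatter), so on this sulfur, whose other neighbour is a saturated chain carbon, 5-methyl-1,3,4-thiadiazol-2-yl and 5-methyl-1,3,4-oxadiazol-2-yl are not interchangeable. For the compounds shown here, the two groups have the same counts of heavy atoms, hetero atoms and hydrogen-bond acceptors, so those counts alone do not fix the value here, something the earlier compounds, with no step between them, could not show. The step is modest and rests on this single pair, and nothing measured here gives a reason for it.

The compounds shown leave open whether a different five-membered ring, such as a 1,2,4-triazole, or an amine or a carboxylic acid in place of the methyl group would move the number further at this position. They also leave open whether the same exchange of oxygen for sulfur gives a step of similar size and direction on a core without the chlorine.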